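A swap on the sulfur of compound 1

This account rests on a few compounds, and the source may have more. Where it says the series, first, only, none or still open, it means among the compounds named here.

Compound 1 `Cc1nnc(SCC(=O)N/N=c2/scc(-c3ccccc3)n2-c2ccccc2)s1` was examined in a functional assay on C6 cells (Rattus norvegicus) for cytotoxicity, read by MTT assay, with a stated time of 24 h; a higher number here means a weaker inhibitor, a lower number a stronger inhibitor. In this assay compound 1 gives > 200 ug/mL as its reading, and this is a limit of the assay and not a number. That limit of > 200 ug/mL in this assay, at which 1 of the 3 values shown sits, is all that fixes its place, and 1 of the 3 values shown sits there.

For compound 2 `Cc1nnc(SCC(=O)N/N=c2/scc(-c3ccc([N+](=O)[O-])cc3)n2-c2ccccc2)s1` the entry reads "not determined" (no result reported) with no result behind it. Compound 3 `Cc1nnc(SCC(=O)N/N=c2/scc(-c3ccc(Cl)cc3)n2-c2ccccc2)s1` gives 28 ug/mL in the same test. Among the measured compounds shown here, the one measured step is an at least 7.1-fold lower number from compound 1 to compound 3 (0.85 log units; beyond the scatter) and it lies beyond the scatter. It comes from chloro in place of hydrogen on an aromatic carbon.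

Compound 4 `Cn1cnnc1SCC(=O)N/N=c1/scc(-c2ccccc2)n1-c1ccccc1` keeps the core of compound 1 and changes another place: 4-methyl-4H-1,2,4-triazol-3-yl in place of 5-methyl-1,3,4-thiadiazol-2-yl on a sulfur in which 4-methyl-4H-1,2,4-triazol-3-yl stands in place of 5-methyl-1,3,4-thiadiazol-2-yl on a sulfur. For the measured compounds named here, no measured step touches that place. The step to compound 3 shows only that this series can move, and it gives no size for this swap. No step beyond the scatter is therefore expected, though the evidence for that is thin. The expected move is a number no higher from compound 1 to compound 4 (the limit leaves the size open) on this estimate. For compound 4 the estimated value is 200 ug/mL with an expected range of 70 ug/mL to 500 ug/mL and another limit reading would be no surprise.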

Compound 4, half-maximal inhibitory concentration: 68.3 ug/mL
Compound 4: middle estimate off by 2.9-fold (0.47 log units), on the high side; the whole stated range lies above it.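

Among the compounds shown here, the swap shows that the place on the sulfur matters in its own right: in this assay the step is an at least 2.9-fold lower number from compound 1 to compound 4 (0.46 log units; beyond the scatter), and the only earlier step, chloro in place of hydrogen on an aromatic carbon, said nothing about this place. The change is small by the counts, since both groups have 6 heavy atoms, one five-membered aromatic ring with 3 hetero atoms, 0 hydrogen-bond donors, 3 hydrogen-bond acceptors and no net charge, and the sulfur of the leaving group is replaced by a third nitrogen in the entering one. The full size of the move stays unknown because compound 1 gives a limit of the assay and not a number: the limit of > 200 ug/mL in this assay, at which 1 of the 4 values shown sits.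

The compounds shown leave open whether another group on this sulfur, such as an ethyl chain, a longer chain carrying an amine, or a carboxylic acid, would keep the reading of compound 4. They also leave open how the chloro and the 4-methyl-4H-1,2,4-triazol-3-yl changes behave together, as compound 3 and compound 4 differ in two places and cannot be compared.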